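The compounds below may be only part of what the source reports. "The series", "measured", "known", "first", "only" and "open" are said of these compounds alone.

Among the compounds with values here, compound 3 `O=C(Nc1ccc(I)cc1F)c1ccccc1O` is the one compound in this set for which an ADME assay on RAW264.7 cells (Mus musculus) for cytotoxicity, read by MTT assay, with a stated time of 24 h (on this read-out higher numbers stand for lower toxicity in this test and lower numbers for higher toxicity in this test), returns an actual number: compound 3 gives 23300 nM. The other two values are limits, not numbers. Compound 1 `O=C(Nc1ccc(Cl)cc1F)c1ccccc1OCc1ccc(F)cc1F` reaches only a limit in this assay, with > 40000 nM. Compound 2 `O=C(Nc1ccc(F)cc1F)c1ccccc1` likewise gives a limit in this assay, > 40000 nM. So compound 3 stands as the sole measured value, and the remaining evidence is the limit of > 40000 nM in this assay, at which 2 of the 3 values shown sit, which says only that neither of those two compounds showed toxicity within the tested range.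

Compound 4 `O=C(Nc1ccc(I)cc1F)c1ccccc1OCc1ccc(F)cc1F` differs from compound 3 in one place: 2,4-difluorobenzyl in place of hydrogen on an oxygen on an aromatic ring. Within the data shown here, no measured pair in this set isolates that change, so the size of the step from compound 3 to compound 4 cannot be read off directly. Among the measured compounds shown here, because the only compounds that carry an ether at that oxygen or a bare amide sit at the limit (the limit of > 40000 nM in this assay, at which 2 of the 3 values shown sit), a move toward lower toxicity, beyond the usual scatter, is expected, a 1.7-fold higher number from compound 3 to compound 4 (0.23 log units; within the scatter). Compound 4 is estimated to give 40000 nM, within 15000 nM to 100000 nM.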

Compound 4, half-maximal cytotoxic concentration: 32600 nM
For compound 4 the middle estimate is 1.2-fold (0.09 log units) above the measured one, and the stated range covers the measured number.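

With 2,4-difluorobenzyl in place of hydrogen on an oxygen on an aromatic ring, this assay shows a 1.4-fold higher number from compound 3 to compound 4 (0.15 log units; within the scatter), so this position takes that whole ring-bearing group with no change that can be told apart from the scatter. Iodo in place of chloro on an aromatic carbon gives an at least 1.2-fold lower number from compound 1 to compound 4 (0.08 log units; that floor lies within the scatter). Compound 1 carries only a limit, so that step is a floor and does not show that the swap of iodo for chloro matters in this test.

As far as these compounds go, how far compound 1 and compound 2 lie past the tested range remains unknown: the limit of > 40000 nM in this assay, at which 2 of the 4 values shown sit. It also remains open whether a different group on that oxygen, such as a methyl, a longer chain, or a chain ending in an amine or a carboxylic acid, would move the number beyond the scatter.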